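This account rests on a few compounds, and the source may have more. Where it says the series, first, only, none or still open, it means among the compounds named here.

Compound 1 `CCCSc1nnc(Cc2ccccc2Oc2ccccc2)[nH]1` gives 139%.
Compound 2 `c1ccc(CSc2nnc(Cc3ccccc3Oc3ccccc3)[nH]2)cc1` gives 139%.
Compound 3 `CCCSc1nnc(Cc2ccc(Cl)cc2Oc2ccccc2Cl)[nH]1` gives 125%.

These three compounds have been measured in a functional assay on the whole organism (strain NMRI) with Mus musculus as the target, with a stated time of 60 min, at a dose of 10 mg/kg by the intraperitoneal route; on this read-out higher numbers stand for a stronger effect at the one dose given and lower numbers for a weaker effect. Compound 1 and compound 2 differ in one place only: phenyl in place of ethyl on a saturated chain carbon bound to a sulfur. That change made a step of no change at the digits printed from compound 1 to compound 2 (within the scatter). Compound 3 has a different core from compound 1; the difference between the two cores is not broken down here. Among the three numbers compound 3 stands lowest, and its gap to compound 1 and to compound 2 lies beyond the scatter in each case.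

Compound 4 `Clc1ccc(Cc2nnc(SCc3ccccc3)[nH]2)c(Oc2ccccc2Cl)c1` has not yet been measured in this assay. It differs from compound 3 in this way: phenyl in place of ethyl on a saturated chain carbon bound to a sulfur. The place of the change is the same, word for word, as in the pair of compound 1 and compound 2, so this is the same change, now made on the core of compound 3 rather than on the core of compound 1. The change occurs twice among the compounds shown, and only one of the two occurrences has a number behind it.

The expectation for compound 4 therefore rests on a single precedent: compound 1 and compound 2, where the change gave no change at the digits printed from compound 1 to compound 2 (within the scatter). On that basis the step for compound 4 is expected to be small, estimated as no change at the digits printed from compound 3 to compound 4 (within the scatter). Compound 4 is estimated at 125%, expected to fall between 108% and 142%.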

Compound 4, a percentage reported as activity, at one dose (the size of the read-out at that dose, not a potency): 122%
For compound 4 the middle estimate is 3 percentage points above the measured one, within the range that was stated.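

In this assay, phenyl in place of ethyl on a saturated chain carbon bound to a sulfur, which can also be read as propylsulfanyl to benzylsulfanyl, gave a number 3 percentage points lower from compound 3 to compound 4 (within the scatter). The change therefore behaved on the core of compound 3 as it had on the core of compound 1, and the two steps do not differ: the same change on two cores in this assay, no change at the digits printed (within the scatter) from compound 1 to compound 2 and a number 3 percentage points lower (within the scatter) from compound 3 to compound 4, 3 percentage points apart, within the scatter of two such steps

This shows only that, on these two cores and at the one dose given, the exchange left the read-out within the scatter; it does not show that the two chains are equal in potency, since a read-out at one dose is not a potency, and two cores are too few to support a rule for the whole series.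

The compounds shown leave open how the read-out responds when the group on the sulfur is something other than propyl or benzyl, such as a longer chain, an amine or a carboxylic acid. They also leave open whether the exchange would stay this small on a third core or at other doses.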